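Aryl Change in the Trimethoxyphenyl Cinnamate Series

The compounds below may be only part of what the source reports. "The series", "measured", "known", "first", "only" and "open" are said of these compounds alone.

Measured so far:
compound 1 `COc1cc(OC)c(OC)cc1/C=C/COC(=O)/C=C/c1cccc(Br)c1` — 100%
compound 2 `COc1cc(OC)c(OC)cc1/C=C/COC(=O)/C=C/c1cc(OC)c(OC)c(OC)c1OC` — 100%

Both compounds share a core and differ only in the aryl group at the far end of the ester chain. In a functional assay on the whole organism (strain Kunming) with Mus musculus as the target, with a stated time of 0.5 h, at a dose of 300 mg/kg by the intraperitoneal route (a higher number here means a weaker effect of the compound at the dose given, a lower number a stronger effect), compound 1 gives 100% and compound 2 gives 100%. Compound 1 therefore stands level with compound 2 at the digits recorded; the two values lie within the scatter of each other, so nothing can be said about an order between them.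

Compound 3 `COc1cc(OC)c(OC)cc1/C=C/COC(=O)/C=C/c1ccccc1Cl` is not yet measured in this assay. It differs from compound 1 in one place only: 2-chlorophenyl in place of 3-bromophenyl on a double-bonded chain carbon bound to a double-bonded chain carbon. For the measured compounds named here, no step between measured compounds is available that would show what this kind of aryl change does; the only guide is that two different aryl groups, compound 1 and compound 2, both sit at the same reading.

On that basis no step beyond the scatter is expected from compound 1 to compound 3, and compound 3 is estimated at 100% (range 85% to 100%), which means an expected step of no change at the digits printed from compound 1 to compound 3 (within the scatter).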

Compound 3, a percentage reported as activity, at one dose (the size of the read-out at that dose, not a potency): 100%
Compound 3: the middle estimate sits on the measured number at the digits printed, and the stated range covers the measured number.
By their numbers in this assay, from the lowest: compounds 1, 2 and 3 (each within the scatter of the next).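

In this assay, for the compounds shown here, the only step so far between compounds that differ in one place is no change at the digits printed from compound 1 to compound 3 (within the scatter), with 2-chlorophenyl in place of 3-bromophenyl on a double-bonded chain carbon bound to a double-bonded chain carbon. The earlier pair showed only that two differently substituted aryl groups share a reading, whereas this step shows that this reading also holds when the halogen and its ring position change together, with the heavy-atom count of the group unchanged. The two changes come as one step, so their separate contributions cannot be read, and no supporting measurement bears on the result.

On these data alone, all three compounds carry a substituted phenyl at this place on the shared core, so it remains open whether any other kind of group there would move the reading away from this level, for example a dimethylamino group on the phenyl, a carboxylic acid, or a longer chain in place of the aryl group. Also open, as far as these compounds go, is whether a change elsewhere, such as an amide in place of the ester, would do so.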